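Swapping the Phenyl Group on a Shared Core

This account rests on a few compounds, and the source may have more. Where it says the series, first, only, none or still open, it means among the compounds named here.

Three compounds share one core and differ only in a substituted phenyl group. In a functional assay on PANC-1 cells (Homo sapiens) for inhibition, read by MTT assay, with a stated time of 24 h (on this read-out higher numbers stand for weaker inhibition and lower numbers for stronger inhibition), compound 1 `COc1ccccc1-n1cc(CN2C(=O)C[C@@H]3CC[C@@]2(C)C3(C)C)nn1`, with 2-methoxyphenyl, gives 120 nM. Compound 2 `CC1(C)[C@H]2CC[C@]1(C)N(Cc1cn(-c3cccc(O)c3)nn1)C(=O)C2`, with 3-hydroxyphenyl, gives 280 nM, and compound 3 `Cc1ccccc1-n1cc(CN2C(=O)C[C@@H]3CC[C@@]2(C)C3(C)C)nn1`, with 2-methylphenyl, gives 250 nM. Two steps place compound 3: a 1.1-fold lower number from compound 2 to compound 3 (0.05 log units; within the scatter), and a 2.1-fold higher number from compound 1 to compound 3 (0.32 log units; beyond the scatter). It is thus level with one neighbour and weaker than the other.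

Compound 4 `COc1cccc(-n2cc(CN3C(=O)C[C@@H]4CC[C@@]3(C)C4(C)C)nn2)c1` has not yet been measured. It carries 3-methoxyphenyl in place of 2-methylphenyl on an aromatic nitrogen. Within the data shown here, no tested compound holds this exact group, so the evidence is indirect. Among the measured compounds shown here, compound 1 is the only tested compound with a methoxy group, and the change to methyl gave a 2.1-fold higher number from compound 1 to compound 3 (0.32 log units; beyond the scatter), which hints at a lower number for compound 4. Against that, the 3-hydroxyphenyl group gave a 2.3-fold higher number from compound 1 to compound 2 (0.37 log units; beyond the scatter), so a group named at that position did not match compound 1. Both steps are modest, so only a small fall, probably not beyond the scatter, is expected. In this assay the expected change is a 1.4-fold lower number from compound 3 to compound 4 (0.14 log units; within the scatter). The estimated value for compound 4 is 180 nM, within a range of 85 nM to 380 nM.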

Compound 4, half-maximal inhibitory concentration: 860 nM
Compound 4: middle estimate off by 4.8-fold (0.68 log units), on the low side, and the stated range ends below it.
By their numbers in this assay, from the lowest: compound 1; then compounds 3 and 2 (each within the scatter of the next); then compound 4.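

The two methoxy compounds now mark the ends of the series in this assay: moving from 2-methoxyphenyl to 3-methoxyphenyl on the aromatic nitrogen gives a 7.2-fold higher number from compound 1 to compound 4 (0.86 log units; beyond the scatter) and makes compound 4 the weakest of the four. So the earlier hint that a methoxy group favours stronger inhibition holds only for compound 1, and the place of the group on the phenyl ring matters as well as its presence. With the group kept in the same place, methyl in place of hydrogen on the oxygen gives a 3.1-fold higher number from compound 2 to compound 4 (0.49 log units; beyond the scatter) and so a free hydroxy group is not interchangeable with methoxy here, while the change from 2-methylphenyl to 3-methoxyphenyl gives a 3.4-fold higher number from compound 3 to compound 4 (0.54 log units; beyond the scatter) and thus opens a wider gap than any step among the first three compounds except none of theirs reached this size.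

As far as these compounds go, it remains open how a phenyl ring carrying an amine, a carboxylic acid or a longer chain on the oxygen, such as ethoxy, would behave on the same shared core. What lies behind these steps also stays open, as nothing measured here speaks to it.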